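This account rests on a few compounds, and the source may have more. Where it says the series, first, only, none or still open, it means among the compounds named here.

Measured so far, in a functional assay on Daudi cells (Homo sapiens) for inhibition, read by resazurin assay, with a stated time of 24 h, tested at 100 uM; a higher number here means more inhibition at the concentration tested (going by the name of the read-out), a lower number less inhibition:
Compound 1 `NC(=O)c1ccccc1Nc1cccc(-c2ccccc2)c1` gives 108%.
Compound 2 `NC(=O)c1ccccc1Nc1cccc(Oc2ccccc2)c1` gives 103%.

Both measured compounds give a high number in this assay, and the step of a number 5 percentage points lower from compound 1 to compound 2 (within the scatter) is within the scatter, so compound 2 stands level with compound 1 and neither can be set apart on this read-out. Compound 3 `NC(=O)c1ccccc1Nc1cccc(/C=C/C(=O)O)c1` has not yet been measured. It differs from compound 2 in one place: 2-carboxyethenyl in place of phenoxy on an aromatic carbon. Among the compounds with values here, the only measured step, a number 5 percentage points lower from compound 1 to compound 2 (within the scatter), swaps one ring for another ring and says little about bringing in an open chain such as 2-carboxyethenyl. Within the data shown here, with no comparable step on record, the expectation for compound 3 rests only on the fact that both measured compounds give a high number in this assay, with a wide allowance for a drop. The step of a number 18 percentage points lower from compound 2 to compound 3 (beyond the scatter) is estimated as a modest loss. Compound 3 is therefore expected to give 85%, in a range from 35% to 110%.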

Compound 3, a percentage reported as inhibition, at one concentration (the size of the read-out at that concentration, not a potency): 0%
For compound 3 the middle estimate is 85 percentage points above the measured one; the measured number lies below the stated range.
By their numbers in this assay, from the lowest: compound 3; then compounds 2 and 1 (each within the scatter of the next).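

Until now this position on the ring had carried only phenyl or phenoxy, and the two could not be told apart, so it was not clear how much the group there mattered. In this assay, replacing either ring with the open chain 2-carboxyethenyl brings a number 103 percentage points lower from compound 2 to compound 3 (beyond the scatter) and a number 108 percentage points lower from compound 1 to compound 3 (beyond the scatter) and removes the inhibition, so at this position, meta to a large group, the result depends strongly on which group is present. Nothing at hand indicates what lies behind this loss.

The compounds shown cannot separate the loss of the ring from the arrival of the carboxylic acid or the double bond within the chain. A methyl ester on the same chain, a saturated propanoic acid chain or a simple amine at this position would each help to tell these apart.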